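The source may report more compounds than this note shows. Statements on the series, on what has been measured and on what is new or still open speak of the compounds shown alone.

Within the data shown here, in a functional assay on A2780 cells (Homo sapiens) for antiproliferative activity, read by MTT assay, with a stated time of 72 h (a higher number here means a weaker inhibitor, a lower number a stronger inhibitor), compound 1 (`O=C(CCCCCONC(=O)Nc1cccc2ccccc12)NO`) reads 7600 nM and lies within the scatter of compound 2 (`Cc1ccc2cccc(NC(=O)NOCCCCCC(=O)NO)c2n1`) at 4300 nM on the only two numbers available. Compound 3 (`CN(O)C(=O)CCCCCONC(=O)Nc1cccc2ccccc12`) keeps the core of compound 1, with methyl in place of hydrogen on an amide-type nitrogen. Among the measured compounds shown here, no measured pair shows this change, so its size rests on judgement alone. A clear step to a higher number in this assay, meaning a weaker inhibitor, is expected (a 3.9-fold higher number from compound 1 to compound 3 (0.60 log units; beyond the scatter)). For compound 3 the estimated value is 30000 nM (range 11000 nM to 80000 nM).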

Compound 3, half-maximal inhibitory concentration: 46800 nM
Beside the measured number, compound 3's estimate is 1.6-fold (0.19 log units) below it; low and high end bracket the measured number.
By their numbers in this assay, from the lowest: compounds 2 and 1 (each within the scatter of the next); then compound 3.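

Methyl in place of hydrogen on an amide-type nitrogen, the change from hydroxycarbamoyl to hydroxy(methyl)carbamoyl, now has a measured size at this position. In this assay it gives a 6.2-fold higher number from compound 1 to compound 3 (0.79 log units; beyond the scatter) and so weakens inhibition on this single pair. No measured evidence here accounts for the step.

On these data alone, whether ethyl on the same nitrogen would read nearer compound 1 or compound 3 stays open. Also open, as far as these compounds go, is how a carboxylic acid in place of the hydroxycarbamoyl group would read.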